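A few compounds are considered here, and "the series" means these few. Any claim that something is new, unique, unknown or untested is made for them only; others in the source may bear on it.

The compounds measured so far in an ADME assay on HEK-293T cells (Homo sapiens) for cytotoxicity, read by MTT assay, with a stated time of 72 h; a higher number here means a weaker inhibitor, a lower number a stronger inhibitor:

Compound 1, `O=C(Nc1nc2ccccc2s1)c1cn(-c2ccccc2)nc1-c1ccccc1`. In this assay compound 1 gives > 50000 nM, which is a limit of the assay rather than a number.
Compound 2, `O=C(Nc1nc2ccc(F)cc2s1)c1cn(-c2ccccc2)nc1-c1ccccc1`. Compound 2 gives 17600 nM.
Compound 3, `O=C(Nc1nc2ccccc2s1)c1cn(-c2ccccc2)nc1-c1ccc(F)cc1`. Compound 3 gives 33400 nM.

Among the two real numbers, compound 3 has the higher one, and compound 2 sits close to it, within the usual scatter, so the two cannot be ordered. Compound 4, `O=C(Nc1nc2ccc(F)cc2s1)c1cn(-c2ccccc2)nc1-c1ccc(F)cc1`, differs from compound 3 by fluoro in place of hydrogen on an aromatic carbon.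

The same change has been seen once already: an at least 2.8-fold lower number from compound 1 to compound 2 (0.45 log units; beyond the scatter), a step that is read only as a floor because of the limit of > 50000 nM in this assay, at which 1 of the 3 values shown sits. The other measured step, an at least 1.4-fold lower number from compound 1 to compound 3 (0.17 log units; that floor lies within the scatter), concerns a different fluorine and therefore says little about this one. On the strength of the first step, a lower number is expected for compound 4 than for compound 3, of at least modest size and possibly more.

The expected step is a 2.8-fold lower number from compound 3 to compound 4 (0.44 log units; beyond the scatter), and compound 4 is estimated at 12000 nM, between 5000 nM and 30000 nM.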

Compound 4, half-maximal inhibitory concentration: 16700 nM
Estimate against measurement, compound 4: 1.4-fold (0.14 log units) below, and the stated range covers the measured number.
By their numbers in this assay, from the lowest: compounds 4, 2 and 3 (each within the scatter of the next). At a limit, above all of these: compound 1.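

In this assay, replacing 1,3-benzothiazol-2-yl with 6-fluoro-1,3-benzothiazol-2-yl gives a 2.0-fold lower number from compound 3 to compound 4 (0.30 log units; within the scatter), so on this second core the change does not clear the usual scatter, whereas the earlier step on the core of compound 1 did, though it could be read only as a floor: the same change on two cores in this assay, an at least 2.8-fold lower number (0.45 log units; beyond the scatter) from compound 1 to compound 2 and a 2.0-fold lower number (0.30 log units; within the scatter) from compound 3 to compound 4; the limit leaves it open whether they differ The other fluorine, placed on compound 2, gives a 1.1-fold lower number from compound 2 to compound 4 (0.02 log units; within the scatter), so once the 6-fluoro group is present, that further fluorine makes no readable difference: the same change on two cores in this assay, an at least 1.4-fold lower number (0.17 log units; that floor lies within the scatter) from compound 1 to compound 3 and a 1.1-fold lower number (0.02 log units; within the scatter) from compound 2 to compound 4; the limit leaves it open whether they differ Compounds 2, 3 and 4 therefore cannot be told apart here, and carrying two fluorines rather than one brings no separable change among them.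

On these data alone, compound 1 gives > 50000 nM, which is a limit and not a number, so the true size of both steps that start from it stays open: the limit of > 50000 nM in this assay, at which 1 of the 4 values shown sits. Also open is whether a different group on this same aromatic carbon, such as chloro, methoxy or an amine, would move the number any further than fluoro does.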